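Trifluoromethoxy for trifluoromethyl on two related cores

The compounds below may be only part of what the source reports. "The series", "measured", "known", "first", "only" and "open" are said of these compounds alone.

Measured compounds:
- compound 1, `CC(O)(CSc1ccc(C(F)(F)F)cc1)C(=O)Nc1ccc(S(F)(F)(F)(F)F)cc1`: 17000 nM
- compound 2, `CC(O)(CSc1ccc(OC(F)(F)F)cc1)C(=O)Nc1ccc(S(F)(F)(F)(F)F)cc1`: 16100 nM
- compound 3, `CC(O)(COc1cccc(C(F)(F)F)c1)C(=O)Nc1cccc(S(F)(F)(F)(F)F)c1`: 28800 nM

All three compounds were tested in a functional assay on LNCaP cells (Homo sapiens) for antiproliferative activity, read by propidium iodide staining, with a stated time of 96 h; a lower number here means a stronger inhibitor, a higher number a weaker inhibitor. Compound 1 and compound 2 share one core and differ by trifluoromethoxy in place of trifluoromethyl on an aromatic carbon. The step of a 1.1-fold lower number from compound 1 to compound 2 (0.02 log units; within the scatter) is a small one, and the two values are not separable from each other. Compound 3 carries a different core, and the difference between the two cores is not broken down here; its value and those of compound 1 and compound 2 lie within the usual scatter of each other, so no order among the three is claimed.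

Compound 4, `CC(O)(COc1cccc(OC(F)(F)F)c1)C(=O)Nc1cccc(S(F)(F)(F)(F)F)c1`, is not yet measured. It differs from compound 3 by trifluoromethoxy in place of trifluoromethyl on an aromatic carbon. This is the same kind of change as that from compound 1 to compound 2, but not the same: in compound 2 the entering group sits para to a large group, whereas in compound 4 it sits meta to a large group, and the core differs as well.

Among the measured compounds shown here, the expectation for compound 4 rests on the one precedent, the step from compound 1 to compound 2 being a 1.1-fold lower number from compound 1 to compound 2 (0.02 log units; within the scatter), and on the value of compound 3, 28800 nM. On that basis the step from compound 3 to compound 4 in this assay is expected to be a 1.1-fold lower number from compound 3 to compound 4 (0.04 log units; within the scatter), close to the earlier one. For the measured compounds named here, the estimate for compound 4 is therefore 26000 nM, with a range from 12000 nM to 55000 nM, the width reflecting the change of core and of place, for which no second precedent exists.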

Compound 4, half-maximal inhibitory concentration: 15200 nM
Beside the measured number, compound 4's estimate is 1.7-fold (0.23 log units) above it; measured number inside the range.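

In this assay, trifluoromethoxy in place of trifluoromethyl gives a 1.9-fold lower number from compound 3 to compound 4 (0.28 log units; within the scatter), so this pair, like the earlier one, shows no separable effect of the change. Set side by side, the two steps cannot be told apart, and the change reads the same on both cores within the limits of these data: the same change on two cores in this assay, a 1.1-fold lower number (0.02 log units; within the scatter) from compound 1 to compound 2 and a 1.9-fold lower number (0.28 log units; within the scatter) from compound 3 to compound 4, 1.8-fold (0.25 log units) apart, within the scatter of two such steps This does not show that the change is neutral on every core in the series, since it rests on two pairs only, and those pairs differ in both core and the place of the entering group, so the two influences cannot be separated and any small effect of either would stay hidden in the scatter.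

From the compounds shown here alone, the aromatic position in these pairs carries only trifluoromethyl or trifluoromethoxy, so it remains open whether a nitrile, an amine or a carboxylic acid there would give a step beyond the scatter. Also open is how much the difference between the two cores contributes on its own, as no pair shown isolates a single part of it, such as the sulfur or oxygen link.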